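Methyl for fluoro on the amide-side ring of compound 3

The source may hold more compounds than are shown below. What is called first, only, known or untested is meant among the compounds shown, and "the series" means these compounds.

Among the compounds with values here, in a functional assay on HEK293 cells for agonist activity at probable G-protein coupled receptor 27 (Homo sapiens), read by a luciferase reporter and beta-arrestin recruitment, with a stated time of 10 min (on this read-out lower numbers stand for smaller maximal responses and higher numbers for larger maximal responses), compound 3 `O=C(Nc1ccc(S(=O)(=O)Nc2ccccc2)cc1)c1ccc(Br)cc1F` gives 67%, the higher of the two numbers measured so far. Compound 1 `CN(c1ccccc1)S(=O)(=O)c1ccc(NC(=O)c2ccc(Cl)cc2Cl)cc1` gives 50%, a result a good way lower, beyond the usual scatter. Compound 2 `O=C(Nc1ccc(S(=O)(=O)NCc2ccccc2)cc1)c1ccc(Cl)cc1Cl` has "not determined" (no result reported), so no number stands for it. Compound 4 `Cc1cc(Br)ccc1C(=O)Nc1ccc(S(=O)(=O)Nc2ccccc2)cc1` has not been measured yet. It differs from compound 3 by one change on the ring bearing the bromo group: methyl in place of fluoro on an aromatic carbon. Within the data shown here, no measured pair shows this particular swap, so nothing here says how large its effect is. A small step from compound 3 to compound 4, within the scatter, is expected, and on that basis compound 4 is estimated at 63%, in a range from 42% to 84%, that is a change of a number 4 percentage points lower from compound 3 to compound 4 (within the scatter).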

Compound 4, largest response reached (Emax), in percent of the reference or control that the assay uses: 103%
Compound 4: middle estimate off by 40 percentage points, on the low side; the measured number lies above the stated range.
By their numbers in this assay, from the lowest: compound 1; then compound 3; then compound 4.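

In this assay, replacing one heavy atom with another at this ring position gives a number 36 percentage points higher from compound 3 to compound 4 (beyond the scatter). Within the data shown here, the earlier compounds differed in more than one place, so this is the first clean sign that the position, ortho to a large group, strongly affects the maximal response. Nothing measured here explains why methyl outperforms fluoro.

The compounds shown leave open whether an ethyl group, a methoxy group or an amine on this carbon would match methyl. They also leave open whether methyl would have a similar effect on the core of compound 1.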